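Branching at the indole nitrogen in a 5-alpha-reductase series

A few compounds are considered here, and "the series" means these few. Any claim that something is new, unique, unknown or untested is made for them only; others in the source may bear on it.

Three measured compounds share one core and differ only in the group on the aromatic nitrogen. Compound 1 `CCCCn1ccc2cc(/C(C)=C/C(=O)Nc3ccccc3OCCCC(=O)O)ccc21` gives 43 nM in an assay on Prostate gland for inhibition of steroid 5-alpha-reductase (Rattus norvegicus); a higher number here means a weaker inhibitor, a lower number a stronger inhibitor. Compound 2 `CCCCCCn1ccc2cc(/C(C)=C/C(=O)Nc3ccccc3OCCCC(=O)O)ccc21` gives 77 nM, and the step of a 1.8-fold higher number from compound 1 to compound 2 (0.25 log units; within the scatter) corresponds to ethyl in place of hydrogen on a saturated chain carbon, four bonds along the chain from an aromatic nitrogen. Compound 3 `CCCCC(CC)n1ccc2cc(/C(C)=C/C(=O)Nc3ccccc3OCCCC(=O)O)ccc21` gives 7.1 nM; its core differs from that of compound 1 by 1-ethylpentyl in place of butyl on an aromatic nitrogen, and it shows a 6.1-fold lower number from compound 1 to compound 3 (0.78 log units; beyond the scatter) and an 11-fold lower number from compound 2 to compound 3 (1.04 log units; beyond the scatter). Compound 4 `CCCCC(CCCC)n1ccc2cc(/C(C)=C/C(=O)Nc3ccccc3OCCCC(=O)O)ccc21` is not yet measured; it differs from compound 3 by ethyl in place of hydrogen on a saturated chain carbon, three bonds along the chain from an aromatic nitrogen, the same kind of change as from compound 1 to compound 2, but three bonds rather than four bonds along the chain from the aromatic nitrogen. Compound 4 is expected to show a 1.5-fold higher number from compound 3 to compound 4 (0.19 log units; within the scatter), a step near the earlier one, because a 1.8-fold higher number from compound 1 to compound 2 (0.25 log units; within the scatter) stayed within the scatter. Compound 4 is therefore estimated at 11 nM, between 4 nM and 30 nM.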

Compound 4, half-maximal inhibitory concentration: 21 nM
Compound 4: the middle estimate sits 1.9-fold (0.28 log units) below what was measured; measured number inside the range.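

Set side by side in this assay, the two ethyl-for-hydrogen steps cannot be told apart, so the change carries over to the branched core at a size compatible with the earlier step: the same change on two cores in this assay, a 1.8-fold higher number (0.25 log units; within the scatter) from compound 1 to compound 2 and a 3.0-fold higher number (0.47 log units; beyond the scatter) from compound 3 to compound 4, 1.7-fold (0.22 log units) apart, within the scatter of two such steps. Only the new step, a 3.0-fold higher number from compound 3 to compound 4 (0.47 log units; beyond the scatter), lies beyond the scatter, and 1-butylpentyl still gives lower numbers than hexyl or butyl, with a 3.7-fold lower number from compound 2 to compound 4 (0.56 log units; beyond the scatter) and a 2.0-fold lower number from compound 1 to compound 4 (0.31 log units; beyond the scatter). This rests on a single pair of steps, three bonds and four bonds along the chain from the aromatic nitrogen, and does not show that the change has one fixed size across the series.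

From the compounds shown here alone, how a cyclohexyl or 1-methylethyl group on the aromatic nitrogen would compare remains open.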